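Demethylation of the methoxy group in compound 2

The source may hold more compounds than are shown below. What is called first, only, known or untested is meant among the compounds shown, and "the series" means these compounds.

Two members of this series have been run in a functional assay on UACC-62 cells (Homo sapiens) for cytotoxicity, read by sulforhodamine B assay, with a stated time of 48 h, tested at 1 uM; on this read-out higher numbers stand for a weaker effect at the one concentration tested and lower numbers for a stronger effect. Compound 1 `Cc1cc(O)cc(-c2nn(CC#N)cc2-c2ccnc(-c3ccc(Oc4ccccc4)cc3)c2)c1` gives 33% in this assay. Compound 2 `COc1cc(C)cc(-c2nn(CC#N)cc2-c2ccnc(-c3ccc(N(C)C)cc3)c2)c1` gives 12% in this assay, the lowest of the two numbers; compound 1 stands higher by a margin beyond the usual scatter. Compound 1 and compound 2 differ in two places at once, so their gap cannot be assigned to either change alone.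

Compound 3 `Cc1cc(O)cc(-c2nn(CC#N)cc2-c2ccnc(-c3ccc(N(C)C)cc3)c2)c1` has not yet been measured. It differs from compound 2 by hydrogen in place of methyl on an oxygen on an aromatic ring. Among the measured compounds shown here, the resulting 3-hydroxy-5-methylphenyl group is the one carried by compound 1, while the 4-(dimethylamino)phenyl side is kept from compound 2. For the measured compounds named here, no measured pair in the set isolates this methoxy-to-hydroxy change, so its size has to be guessed.

Given that compound 2 sits at 12% and that compound 1, which also carries the hydroxy group, sits at 33%, a modest step upward is expected for compound 3, a number 8 percentage points higher from compound 2 to compound 3 (within the scatter), though one within the scatter would not be surprising. Compound 3 is expected to give about 20% in this assay, between 8% and 40%.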

Compound 3, a percentage reported as activity, at one concentration (the size of the read-out at that concentration, not a potency): 10%
Estimate against measurement, compound 3: 10 percentage points above, and the stated range covers the measured number.
By their numbers in this assay, from the lowest: compounds 3 and 2 (each within the scatter of the next); then compound 1.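

On the 3-methoxy-5-methylphenyl group, the change from methoxy to hydroxy gives no readable difference in this assay, with a number 2 percentage points lower from compound 2 to compound 3 (within the scatter), so the dimethylamino compounds do not separate on this change. With the 3-hydroxy-5-methylphenyl group now held constant, dimethylamino in place of phenoxy on an aromatic carbon gives a number 23 percentage points lower from compound 1 to compound 3 (beyond the scatter) in this assay, a modest step beyond the scatter. The gap between compound 1 and compound 2, previously tied to two changes at once, therefore tracks the phenoxy and dimethylamino difference in these three compounds, while no available evidence explains either the flat step or the larger one.

From the compounds shown here alone, it remains open whether methoxy and hydroxy also read alike when the phenoxy group is present, as the flat step rests on a single pair carrying dimethylamino. Also open, going by these compounds, is how this oxygen responds to a longer chain such as ethoxy or to its replacement by an amine or a carboxylic acid, and how the aromatic carbon responds to a morpholine ring or a primary amine in place of dimethylamino.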